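Cytotoxicity of one aryl position on the shared core

The source may hold more compounds than are shown below. What is called first, only, known or untested is meant among the compounds shown, and "the series" means these compounds.

Compound 3 `COc1cccc(CNCCCNc2ccnc3cc(Oc4cccc(N(C)C)c4)ccc23)c1O` gives 7300 nM in an ADME assay on HepG2 cells (Homo sapiens) for cytotoxicity, read by luminescence, CellTiter-Glo and ATP content, with a stated time of 72 h (a lower number here means that less compound is needed, a higher number that more compound is needed for the effect), and sits within the scatter of both other measured compounds, nearest to compound 2 `COc1cccc(CNCCCNc2ccnc3cc(Cc4ccc(C#N)cc4)ccc23)c1O`, which gives 7150 nM, and furthest from compound 1 `COc1cccc(CNCCCNc2ccnc3cc(CCC(C)C)ccc23)c1O`, which gives 5390 nM. Compound 4 `COc1ccc(-c2ccc3c(NCCCNCc4cccc(OC)c4O)ccnc3c2)cc1` differs from compound 3 at a single aromatic carbon of the shared core: 4-methoxyphenyl in place of 3-(dimethylamino)phenoxy on an aromatic carbon. The three measured steps all vary this same position, and each stayed within the scatter: a 1.3-fold higher number from compound 1 to compound 2 (0.12 log units; within the scatter), a 1.4-fold higher number from compound 1 to compound 3 (0.13 log units; within the scatter), and a 1.0-fold higher number from compound 2 to compound 3 (0.01 log units; within the scatter). Since the change to compound 4 is of the same kind, no step beyond the scatter is expected in this assay. Compound 4 is therefore estimated at 7000 nM, with a range from 3500 nM to 14000 nM. This means an expected step for compound 4 of a 1.0-fold lower number from compound 3 to compound 4 (0.02 log units; within the scatter).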

Compound 4, half-maximal effective concentration: 1600 nM
The estimate for compound 4 lay 4.4-fold (0.64 log units) above the measured number; the measured number lies below the stated range.
By their numbers in this assay, from the lowest: compound 4; then compounds 1, 2 and 3 (each within the scatter of the next).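

In this assay, going by these compounds alone, the 4-methoxyphenyl group takes this aromatic carbon beyond the scatter for the first time, with a 4.6-fold lower number from compound 3 to compound 4 (0.66 log units; beyond the scatter) and a 4.5-fold lower number from compound 2 to compound 4 (0.65 log units; beyond the scatter) and a 3.4-fold lower number from compound 1 to compound 4 (0.53 log units; beyond the scatter), all modest. Of the four compounds, compound 4 alone carries its aromatic ring on the core with no linking atom, so the methoxy group and the direct attachment cannot be told apart. Nothing available accounts for the step. On these data alone, it remains open whether an unsubstituted phenyl or a 4-methoxyphenoxy group would give a similar number.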